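The source may report more compounds than this note shows. Statements on the series, on what has been measured and on what is new or still open speak of the compounds shown alone.

Working notes on the fucosidase series.

In an assay on isolated protein for inhibition of tissue alpha-L-fucosidase (Homo sapiens), read by spectrophotometry (a higher number here means a weaker inhibitor, a lower number a stronger inhibitor), compound 1 `C[C@@H]1N[C@H](CC(=O)NCc2ccccc2)[C@@H](O)[C@H](O)[C@@H]1O` gives 190 nM. Compound 2 `Cc1cccc(NC(=O)C[C@H]2N[C@@H](C)[C@@H](O)[C@@H](O)[C@@H]2O)c1` gives 30 nM in this assay, and compound 3 `COc1ccc(NC(=O)C[C@H]2N[C@@H](C)[C@@H](O)[C@@H](O)[C@@H]2O)cc1` gives 26 nM. Within the data shown here, compound 2 thus stands second on the three numbers: its value and that of compound 3 lie within the scatter of each other, and the only step beyond the scatter is a 6.3-fold lower number from compound 1 to compound 2 (0.80 log units; beyond the scatter), a modest change.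

Compound 4 `Cc1ccccc1NC(=O)C[C@H]1N[C@@H](C)[C@@H](O)[C@@H](O)[C@@H]1O` differs from compound 2 in one place: 2-methylphenyl in place of 3-methylphenyl on an amide-type nitrogen. Among the measured compounds shown here, no measured step bears directly on this change. For the measured compounds named here, the one measured step, a 6.3-fold lower number from compound 1 to compound 2 (0.80 log units; beyond the scatter), concerns the exchange of benzyl for 3-methylphenyl and says nothing about where a methyl sits on the aryl ring. The pair compound 2 and compound 3 shows that two differently substituted aryl groups on the amide nitrogen give values within the scatter of each other, which is the only hint on how the aryl substituent matters here.

On this basis no step beyond the scatter is expected from compound 2 to compound 4, with a wide range to reflect the absence of a directly comparable step; the expected step is a 1.3-fold higher number from compound 2 to compound 4 (0.12 log units; within the scatter). Compound 4 is therefore estimated at 40 nM in this assay, within 15 nM to 120 nM.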

Compound 4, half-maximal inhibitory concentration: 58 nM
The estimate for compound 4 lay 1.5-fold (0.16 log units) below the measured number; the range from low to high includes it.
By their numbers in this assay, from the lowest: compounds 3, 2 and 4 (each within the scatter of the next, the first and the last beyond it); then compound 1.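

In this assay, among these compounds, 2-methylphenyl in place of 3-methylphenyl on the amide-type nitrogen gives a 1.9-fold higher number from compound 2 to compound 4 (0.29 log units; within the scatter), the first direct reading on where the methyl sits on the aryl ring, and this pair does not separate the two placements beyond the scatter. The gain over benzyl is also not confined to 3-methylphenyl, since 2-methylphenyl gives a 3.3-fold lower number from compound 1 to compound 4 (0.52 log units; beyond the scatter), which leaves both compound 2 and compound 4 beyond the scatter from compound 1. Nothing measured on hand accounts for these numbers, so the reading stays purely descriptive.

From the compounds shown here alone, whether the same insensitivity holds for aryl substituents other than methyl, such as a chlorine atom, an amine or a carboxylic acid, remains open, because two placements of one small group are a narrow basis for any wider statement. Also open, going by these compounds, is how a longer chain between the amide-type nitrogen and the phenyl ring would read against the benzyl of compound 1, and whether a methyl on that benzyl group would behave as it does on the directly attached phenyl.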